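The source may report more compounds than this note shows. Statements on the series, on what has been measured and on what is new or still open speak of the compounds shown alone.

Measured so far in an assay on cells for agonist activity at ecdysone receptor (Bombyx mori), read by a luciferase reporter, with a stated time of 24 h; on this read-out higher numbers stand for an effect only at larger amounts of compound and lower numbers for an effect already at smaller amounts:
compound 1 `COc1cccc(C(=O)NN(C(=O)c2ccccc2Cl)C(C)(C)C)c1` gives 52.5 nM;
compound 2 `COc1cccc(C(=O)NN(C(=O)c2cc(C)cc(C)c2)C(C)(C)C)c1` gives 66.1 nM.

Compound 2 stands at the higher of these two numbers, yet the step of a 1.3-fold higher number from compound 1 to compound 2 (0.10 log units; within the scatter) lies within the scatter, so the two compounds cannot be told apart. Compound 3 `Cc1cc(C)cc(C(=O)N(NC(=O)CCC(C)C)C(C)(C)C)c1` is not yet measured. Compared with compound 2, it carries isopentyl in place of 3-methoxyphenyl on a carbonyl carbon. Among the measured compounds shown here, no measured step bears directly on this change: the only measured step, a 1.3-fold higher number from compound 1 to compound 2 (0.10 log units; within the scatter), alters the ring on the other carbonyl carbon and shows nothing beyond the scatter, so it gives no guide to the size of a change on this carbonyl carbon. Here a ring gives way to a chain with no ring, and for compound 3 a higher number than for compound 2 is expected, an effect only at larger amounts, with a 9.1-fold higher number from compound 2 to compound 3 (0.96 log units; beyond the scatter) as the estimated step. Compound 3 is therefore expected at 600 nM, within a range from 100 nM to 4000 nM.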

Compound 3, half-maximal effective concentration: 91.2 nM
Compound 3: the middle estimate sits 6.6-fold (0.82 log units) above what was measured; the measured number lies below the stated range.
By their numbers in this assay, from the lowest: compounds 1, 2 and 3 (each within the scatter of the next).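

Among the compounds shown here, this is the first look at the group on this carbonyl carbon, since the earlier step changed a different part of the molecule. In this assay the exchange gives a 1.4-fold higher number from compound 2 to compound 3 (0.14 log units; within the scatter), so here a chain with no ring, isopentyl, cannot be told apart from the aromatic ring of 3-methoxyphenyl, and for these two compounds that ring is not needed to keep the number at this level. No measurement at hand explains why the two groups read alike.

As far as these compounds go, it remains open whether a longer chain such as octyl, or a chain ending in a carboxylic acid or an amine, would also stay within the scatter of compound 2 on this carbonyl carbon. Also open, from the compounds shown here alone, is whether isopentyl would read the same with 2-chlorophenyl in place of 3,5-dimethylphenyl.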